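Trifluoromethoxy on the benzyl ring of a nitrofuran chalcone

This account rests on a few compounds, and the source may have more. Where it says the series, first, only, none or still open, it means among the compounds named here.

Measured so far:
compound 1 `O=C(/C=C/c1ccc([N+](=O)[O-])o1)c1ccc(OCc2ccccc2)cc1` — 515000 nM
compound 2 `O=C(/C=C/c1ccc([N+](=O)[O-])o1)c1ccc(OCc2cccc(Cl)c2)cc1` — 307000 nM

In a toxicity assay on Vero cells (Chlorocebus sabaeus) for cytotoxicity (on this read-out higher numbers stand for lower toxicity in this test and lower numbers for higher toxicity in this test), compound 1 gives 515000 nM, the highest of the two numbers, with compound 2 nearest at 307000 nM. That step, a 1.7-fold lower number from compound 1 to compound 2 (0.22 log units; within the scatter), is the only one on record, and it lies within the scatter, so the two compounds cannot be ranked.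

Compound 3 `O=C(/C=C/c1ccc([N+](=O)[O-])o1)c1ccc(OCc2ccc(OC(F)(F)F)cc2)cc1` has not been tested. It differs from compound 1 by trifluoromethoxy in place of hydrogen on an aromatic carbon. Among the measured compounds shown here, the one measured step bears on it only loosely: a different halogen-bearing group at a different place on the same ring gave a 1.7-fold lower number from compound 1 to compound 2 (0.22 log units; within the scatter), a change within the scatter. A step of similar size or none is therefore expected for compound 3 in this assay, with a slight lean toward a lower number because compound 2 gave a 1.7-fold lower number from compound 1 to compound 2 (0.22 log units; within the scatter). Compound 3 is expected to give 320000 nM, in the range 130000 nM to 750000 nM, which corresponds to an expected step of a 1.6-fold lower number from compound 1 to compound 3 (0.21 log units; within the scatter).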

Compound 3, half-maximal cytotoxic concentration: 335000 nM
Compound 3: the middle estimate sits 1.0-fold (0.02 log units) below what was measured, and the stated range covers the measured number.
By their numbers in this assay, from the lowest: compounds 2, 3 and 1 (each within the scatter of the next).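

In this assay, the new information concerns a larger replacement: hydrogen gives way to trifluoromethoxy, with its 5 heavy atoms, on an aromatic carbon para to a large group, and the result is a 1.5-fold lower number from compound 1 to compound 3 (0.19 log units; within the scatter). Among the compounds shown here, compound 1 and compound 3 therefore cannot be ranked, so at this position even this group produces no step that can be read beyond the scatter. Nothing available explains this result or ties it to any property of the group.

As far as these compounds go, it remains open whether an amine or a carboxylic acid at the same position would also stay within the scatter or would give a step beyond it. Also open, from the compounds shown here alone, is how trifluoromethoxy would read at the place that chlorine holds in compound 2.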